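A Methyl Added to a Compound at the Limit

A few compounds are considered here, and "the series" means these few. Any claim that something is new, unique, unknown or untested is made for them only; others in the source may bear on it.

Measured in a functional assay on HCT-116 cells (Homo sapiens) for inhibition, read by sulforhodamine B assay, with a stated time of 3 days; on this read-out lower numbers stand for stronger inhibition of growth and higher numbers for weaker inhibition of growth:
- compound 1 `Cc1ccc(COc2ccc(C(=O)/C=C/c3ccccc3)cc2)cc1`: > 50000 nM
- compound 2 `O=C(/C=C/c1ccc(F)cc1)c1ccc(OCc2ccccc2)cc1`: > 50000 nM

Both entries are limits of the assay and not numbers. Compound 2 stands at the limit of > 50000 nM in this assay, at which 2 of the 2 values shown sit, so it has no exact value to serve as a starting point.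

Compound 3 `Cc1ccc(COc2ccc(C(=O)/C=C/c3ccc(F)cc3)cc2)cc1` differs from compound 2 by methyl in place of hydrogen on an aromatic carbon, para to a large group, which turns benzyl to 4-methylbenzyl. Among the compounds with values here, no measured pair shows this change on its own.

With compound 2 at the limit of > 50000 nM, no step beyond the usual scatter is expected in this assay, and no direction is favoured. The expected change is a number no higher from compound 2 to compound 3 (the limit leaves the size open). Compound 3 is estimated at 50000 nM, with an expected range of 15000 nM to 100000 nM.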

Compound 3, concentration for 50% growth inhibition: > 50000 nM
Compound 3 gave a limit, no number; the forecaster's own chance of this, stated with the estimate: 70%; the middle value lies on the limit itself.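

Within the data shown here, compound 3 gives only a limit in this assay, not a number, so no step from compound 1 or compound 2 to compound 3 can be read: the limit of > 50000 nM in this assay, at which 3 of the 3 values shown sit.

The compounds shown leave open what either of these two changes does to growth inhibition in this assay.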